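The source may report more compounds than this note shows. Statements on the series, on what has been measured and on what is new or still open speak of the compounds shown alone.

Measured in a functional assay on K562 cells (Homo sapiens) for inhibition, read by sulforhodamine B assay, with a stated time of 48 h; a higher number here means a weaker inhibitor of growth, a lower number a stronger inhibitor of growth:
- Compound 1 `CC1(/C=C/c2ccc(C(F)(F)F)cc2)C=CC(=O)O1`: 652000 nM
- Compound 2 `COc1ccc(/C=C/C2(C)C=CC(=O)O2)c(OC)c1`: > 1000000 nM (a limit)
- Compound 3 `COc1ccc(/C=C/C2(C)C=CC(=O)O2)cc1OC`: > 1000000 nM (a limit)

Compound 3 gives > 1000000 nM in this assay, which is a limit of the assay and not a number. Compound 2 sits at that same limit, so the picture is the limit of > 1000000 nM in this assay, at which 2 of the 3 values shown sit. Only compound 1 has a true number, so the series offers little to build on.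

Compound 4 `COc1ccc(/C=C/C2(C)C=CC(=O)O2)cc1` differs from compound 3 in one place: hydrogen in place of methoxy on an aromatic carbon. In words, hydrogen replaces methoxy on an aromatic carbon, ortho to a methoxy group. Among the compounds with values here, no measured pair shows what such a change does. I expect little or no change beyond the scatter, and any shift should lean towards stronger growth inhibition, since compound 1 reaches only 652000 nM. The expected at least 1.2-fold lower number from compound 3 to compound 4 (0.09 log units; that floor lies within the scatter) is small, and compound 4 may well report only a limit too. For compound 4 the estimated value is 800000 nM, with an expected range of 400000 nM to 1000000 nM.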

Compound 4, concentration for total growth inhibition: > 1000000 nM
Compound 4: a limit, no number; the forecaster's own chance of this, stated with the estimate: 55%; at least 1.2-fold (0.09 log units) between middle value and limit.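

In this assay compound 4 stays at a limit, so removing one methoxy group from this aromatic carbon does not yield a readable number, and the steps from compound 2 and compound 3 to compound 4 cannot be read. Within the data shown here, the one readable step, with methoxy in place of trifluoromethyl on an aromatic carbon, is an at least 1.5-fold higher number from compound 1 to compound 4 (0.18 log units; that floor lies within the scatter), so only its floor is known, and that floor does not clear the usual scatter. The limit now holds most of the series: the limit of > 1000000 nM in this assay, at which 3 of the 4 values shown sit.

Going by these compounds, whether compounds 2, 3 and 4 truly differ from one another remains open. Also open, on these data alone, is whether an amine or a carboxylic acid on this aromatic carbon would give a true number in this assay.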